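Replacing a Phenyl Ester with an Oxan-3-yl Ester

The source may hold more compounds than are shown below. What is called first, only, known or untested is meant among the compounds shown, and "the series" means these compounds.

Measured so far:
compound 1 `NCc1ccc(C(=O)Nc2ccncc2F)cc1-c1cccc(C(=O)Oc2ccccc2)c1` gives 0.117 h
compound 2 `CCCCOC(=O)c1cccc(-c2cc(C(=O)Nc3ccncc3)ccc2CN)c1` gives 0.367 h
compound 3 `NCc1ccc(C(=O)Nc2ccncc2)cc1-c1cccc(C(=O)OCC2CCCC2)c1` gives 0.517 h

Of the three compounds measured in an ADME assay on a cell-free system (plasma, Homo sapiens) for metabolic stability, read by LC-MS (on this read-out higher numbers stand for a longer-lived compound and lower numbers for a shorter-lived compound), compound 1 stands lowest, with 0.117 h; compound 2 and compound 3 both lie beyond the scatter above it. The unmeasured compound 4 `NCc1ccc(C(=O)Nc2ccncc2F)cc1-c1cccc(C(=O)OC2CCCOC2)c1` differs from compound 1 in one place: oxan-3-yl in place of phenyl on an oxygen next to a carbonyl group.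

Going by the values given here, only one measured step touches the same part of the molecule: a 1.4-fold higher number from compound 2 to compound 3 (0.15 log units; within the scatter), a change from one saturated ring to another on a saturated chain carbon bound to an oxygen next to a carbonyl group. It suggests that swapping groups at that position can leave this assay roughly unchanged. Among the compounds with values here, compound 2 and compound 3, which carry such saturated groups there, both show higher numbers than compound 1, but they also lack the fluorine of compound 1, so no single step isolates the ester group. On balance, a modest rise is expected, roughly a 3.0-fold higher number from compound 1 to compound 4 (0.48 log units; beyond the scatter), with wide uncertainty. Compound 4 is therefore estimated at 0.35 h, with a range from 0.12 h to 1 h.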

Compound 4, half-life: 0.3 h
Compound 4: middle estimate off by 1.2-fold (0.07 log units), on the high side, and the stated range covers the measured number.
By their numbers in this assay, from the lowest: compound 1; then compounds 4, 2 and 3 (each within the scatter of the next).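

With the rest of the molecule unchanged, oxan-3-yl in place of phenyl on an oxygen next to a carbonyl group gives a 2.6-fold higher number from compound 1 to compound 4 (0.41 log units; beyond the scatter) in this assay. Going by these compounds alone, this is the first clean reading of the group at this position in the fluorine-bearing compounds, since compounds 2 and 3 differ from compound 1 in more than one place. The earlier step at the ester, a 1.4-fold higher number from compound 2 to compound 3 (0.15 log units; within the scatter), stayed within the scatter, whereas this one shows that a change here can move the half-life beyond it, though no measurement shown explains why.

The compounds shown do not separate losing the aromatic ring from gaining the ring oxygen, and a cyclohexyl ester would address that question. They also leave open how the fluorine acts, as no pair shown differs only there.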